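The source may hold more compounds than are shown below. What is called first, only, known or untested is meant among the compounds shown, and "the series" means these compounds.

In a functional assay on G-361 cells (Homo sapiens) for cytotoxicity, read by fluorescence, with a stated time of 72 h (on this read-out higher numbers stand for weaker inhibition and lower numbers for stronger inhibition), three compounds sharing one core have been measured. Compound 1 `CSc1nc(NCc2ccc(-c3ccccn3)cc2)c2[nH]nc(C(C)C)c2n1` gives 1400 nM, compound 2 `CC(C)c1n[nH]c2c(NCc3ccc(-c4ccccn4)cc3)nc(S(C)(=O)=O)nc12` gives 793 nM, and compound 3 `CC(C)c1n[nH]c2c(NCc3ccc(-c4ccccn4)cc3)nc(N3CCCCC3CCO)nc12` gives 204 nM. That is the lowest of the three numbers, so compound 3 is the strongest inhibitor so far.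

Compound 4 `CC(C)c1n[nH]c2c(NCc3ccc(-c4ccccn4)cc3)nc(NCC(N)CO)nc12` keeps the core and alters only the group on the aromatic carbon between two ring nitrogen atoms: a group of 6 heavy atoms (3 carbon, 2 nitrogen, 1 oxygen; no ring) in place of a group of 9 heavy atoms (7 carbon, 1 nitrogen, 1 oxygen; one six-membered non-aromatic ring with 1 hetero atom), on an aromatic carbon. The measured steps at this same carbon offer a guide. The change from methylsulfanyl to methylsulfonyl gave a 1.8-fold lower number from compound 1 to compound 2 (0.25 log units; within the scatter), while installing 2-(2-hydroxyethyl)piperidin-1-yl gave a 6.9-fold lower number from compound 1 to compound 3 (0.84 log units; beyond the scatter) and a 3.9-fold lower number from compound 2 to compound 3 (0.59 log units; beyond the scatter). For the measured compounds named here, all three are small to modest, but none removes a ring from the group, so no measured step matches this change directly. Compound 4 and compound 3 both keep a nitrogen on that carbon, so no clear move beyond the scatter is expected in this assay, in either direction. The estimated step is a 1.1-fold lower number from compound 3 to compound 4 (0.03 log units; within the scatter). For compound 4, the estimated value is 190 nM, with an expected range from 60 nM to 600 nM.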

Compound 4, half-maximal inhibitory concentration: 1020 nM
Compound 4: the middle estimate sits 5.4-fold (0.73 log units) below what was measured, and the stated range ends below it.
By their numbers in this assay, from the lowest: compound 3; then compounds 2, 4 and 1 (each within the scatter of the next).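

In this assay, keeping a nitrogen on this carbon does not by itself preserve the low number: the open chain of compound 4 brings a 5.0-fold higher number from compound 3 to compound 4 (0.70 log units; beyond the scatter), so the gain seen with 2-(2-hydroxyethyl)piperidin-1-yl does not carry over to this group. The new group instead sits level with methylsulfonyl and methylsulfanyl, at a 1.3-fold higher number from compound 2 to compound 4 (0.11 log units; within the scatter) and a 1.4-fold lower number from compound 1 to compound 4 (0.14 log units; within the scatter), and neither step separates them. Nothing shown here accounts for the gap between the two nitrogen-linked groups.

The two groups differ in both the ring and the chain at once, so the compounds shown cannot say which part matters. A plain piperidin-1-yl group, or an open chain ending in a hydroxyl with no amine, would help pull these parts apart.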